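Inverting One Chain Stereocentre Near the Assay Limit

This account rests on a few compounds, and the source may have more. Where it says the series, first, only, none or still open, it means among the compounds named here.

Compound 1 `Nc1nc2c(ncn2/C=C2\C[C@@H]2[C@H](O)CO)c(=O)[nH]1` gives > 300000 nM in an ADME assay on HFF cells (Homo sapiens) for cytotoxicity, read by neutral red uptake (on this read-out lower numbers stand for higher toxicity in this test and higher numbers for lower toxicity in this test), and this value is a limit, not a number. Compound 2 `Nc1nc2c(ncn2/C=C2/C[C@H]2[C@H](O)CO)c(=O)[nH]1` gives > 300000 nM in this assay, again a limit. Going by the values given here, compound 3 `Nc1nc2c(ncn2/C=C2\C[C@H]2[C@@H](O)CO)c(=O)[nH]1` gives 298000 nM in this assay, the only actual number among the three. Compound 4 `Nc1nc2c(ncn2/C=C2\C[C@H]2[C@H](O)CO)c(=O)[nH]1` relates to compound 3 as follows: the two compounds have the same atoms and bonds and differ only in configuration as drawn: 1 of 3 stereo elements differ; a stereocentre at a saturated chain carbon is drawn R in compound 3 and S in compound 4. Among the compounds with values here, three measured steps bear on this change: a step that the two limits leave unreadable from compound 1 to compound 2, a number no higher from compound 1 to compound 3 (the limit leaves the size open) and a number no higher from compound 2 to compound 3 (the limit leaves the size open). None has a readable size. The last two are the most relevant, as each includes a change at the saturated chain carbon, although each also changes a second stereo element. As far as these compounds go, with no readable step to build on, no change beyond the usual scatter is expected, and the direction stays open. The expected step is a 1.0-fold higher number from compound 3 to compound 4 (0.00 log units; within the scatter). Compound 4 is estimated at 300000 nM, with an expected range of 200000 nM to 450000 nM.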

Compound 4, half-maximal cytotoxic concentration: > 300000 nM
Compound 4 was reported as a limit; the forecaster's own chance of this, stated with the estimate: 70%; the middle value sits exactly at the limit.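

In this assay, inverting the saturated chain carbon alone gives a number no lower from compound 3 to compound 4 (the limit leaves the size open); this is the first step shown that changes only this stereocentre, as the earlier steps to compound 3 each changed a second stereo element as well. Compound 4 gives > 300000 nM, which is a limit and not a number. The steps from compound 1 and from compound 2 to compound 4 cannot be read, and compound 3 remains the only compound with an actual number: the limit of > 300000 nM in this assay, at which 3 of the 4 values shown sit.

As far as these compounds go, how far compounds 1, 2 and 4 lie past the limit stays open, so no order among them can be given. From the compounds shown here alone, all four compounds share the same atoms and bonds, and whether an amine or a carboxylic acid in place of the chain hydroxyl would change the number in this assay also stays open.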